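The compounds below may be only part of what the source reports. "The series", "measured", "known", "first", "only" and "open" are said of these compounds alone.

Measured compounds:
- compound 1, `O=C(CCCc1ccccc1)OC(CCN1CCN(CCCN(c2ccc(F)cc2)c2ccc(F)cc2)CC1)c1ccccc1`, in an assay on membranes from brain for displacement of a labelled ligand from Sigma non-opioid intracellular receptor 1 (Cavia porcellus) (a lower number here means a stronger inhibitor, a higher number a weaker inhibitor), compound 1 gives 246 nM
- compound 2, `C=CC(=O)O[C@@H](Cc1ccccc1)CN1CCN(CCCN(c2ccc(F)cc2)c2ccc(F)cc2)CC1`, in this assay compound 2 gives 45.5 nM

Of the two values, compound 1 carries the higher number, and the gap to compound 2 lies beyond the scatter. The two structures differ in more than one place, so the gap cannot be traced to a single change.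

Compound 3, `C=CC(=O)OC(CCN1CCN(CCCN(c2ccc(F)cc2)c2ccc(F)cc2)CC1)c1ccccc1`, has not yet been measured. It differs from compound 1 in one place: vinyl in place of 3-phenylpropyl on a carbonyl carbon. Going by the values given here, no measured pair isolates this change, so the direction of the step rests on what the two values show. Compound 2, which carries the same vinyl ester group, gives 45.5 nM, but its other differences leave the contribution of the ester open. A small step in this assay is expected, possibly toward a lower number, with a size within or only slightly beyond the scatter: a 1.4-fold lower number from compound 1 to compound 3 (0.14 log units; within the scatter). The estimate for compound 3 is 180 nM, within 60 nM to 600 nM.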

Compound 3, inhibition constant: 87.3 nM
The estimate for compound 3 lay 2.1-fold (0.31 log units) above the measured number, and the stated range covers the measured number.
By their numbers in this assay, from the lowest: compounds 2 and 3 (each within the scatter of the next); then compound 1.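

In this assay, going by these compounds alone, this is the first step that isolates a single change: vinyl in place of 3-phenylpropyl on a carbonyl carbon gives a 2.8-fold lower number from compound 1 to compound 3 (0.45 log units; beyond the scatter). On the core of compound 1, the 3-phenylpropyl group and its aromatic ring are therefore not required for this level of binding, and removing them brings a modest gain rather than a loss. No available measurement bears on the reason for this step.

As far as these compounds go, it remains open which part of the change carries the step: the loss of the ring, the shorter chain or the double bond outside aromatic rings. An ethyl or a phenyl group on the same carbonyl carbon would help separate these, and a single pair on one core cannot show whether the step holds elsewhere in the series.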